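The source may report more compounds than this note shows. Statements on the series, on what has been measured and on what is new or still open speak of the compounds shown alone.

Measured compounds:
Compound 1, `Nc1cc(-c2ccc(Br)cc2)nc2cc(-c3ccc(Cl)cc3)nn12`, in a functional assay on the whole organism (strain Wistar) for inhibition, with Rattus norvegicus as the target, read by paw edema, with stated times of 30 min and 2 h, at a dose of 50 mg/kg by the oral route (a higher number here means more inhibition at the dose given (going by the name of the read-out), a lower number less inhibition), gives 60%.
Compound 2, `Cc1ccc(-c2cc(N)n3nc(-c4ccc(Cl)cc4)cc3n2)cc1`, in this assay gives 75%.
Compound 3, `Cc1ccc(-c2cc3nc(-c4ccc(Cl)cc4)cc(N)n3n2)cc1`, in this assay gives 67.5%.

Compound 3 has the same atoms as compound 2, joined differently; the difference between the two cores is not broken down here. In this assay compound 3 and compound 2, and likewise compound 3 and compound 1, lie within the usual scatter of each other.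

From compound 2 to compound 1 the change is bromo in place of methyl on an aromatic carbon, and it made a step of a number 15 percentage points lower from compound 2 to compound 1 (beyond the scatter). Compound 4, `Nc1cc(-c2ccc(Cl)cc2)nc2cc(-c3ccc(Br)cc3)nn12`, is not yet measured. It differs from compound 3 by bromo in place of methyl on an aromatic carbon, the same change on the core of compound 3, at a place described in the same words.

Because the earlier step was a number 15 percentage points lower from compound 2 to compound 1 (beyond the scatter), compound 4 is expected to move by a number 15 percentage points lower from compound 3 to compound 4 (beyond the scatter). Compound 4 is therefore estimated at 52.5%, between 40% and 65%.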

Compound 4, a percentage reported as inhibition, in the whole organism at one dose (the size of the read-out at that dose, not a potency): 72.5%
Estimate against measurement, compound 4: 20 percentage points below, and the stated range ends below it.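

In this assay, putting bromo in place of methyl on the core of compound 3 gave a step of a number 5 percentage points higher from compound 3 to compound 4 (within the scatter). The change from 4-methylphenyl to 4-bromophenyl therefore cannot be carried from one core to the other in this series as a fixed step: the same change on two cores in this assay, a number 15 percentage points lower (beyond the scatter) from compound 2 to compound 1 and a number 5 percentage points higher (within the scatter) from compound 3 to compound 4, 20 percentage points apart, beyond the scatter of two such steps

This rests on a single pair on each core, and it does not show why the two cores differ or how any other change would carry between them.

From the compounds shown here alone, whether a methoxy group, a nitrile or a carboxylic acid at this place would give matching steps on both cores remains open. Each value is also a response at one dose, which leaves potency on either core open.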